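The source may hold more compounds than are shown below. What is called first, only, known or untested is meant among the compounds shown, and "the series" means these compounds.

Working notes on the series.

Compound 1 `Cc1ccncc1C(=O)N1CC(Oc2cncc(N3C(=O)c4ccc(Cl)cc4C3(C)C)c2)C1` gives 4 nM in an assay on cells for inhibition of cytochrome P450 11B2, mitochondrial (Homo sapiens), read by HTRF; a higher number here means a weaker inhibitor, a lower number a stronger inhibitor. Compound 2 `CCC(=O)N[C@@H]1CCCc2c1cncc2N1C(=O)c2ccc(Cl)cc2[C@@H]1C` gives 6 nM in this assay, and compound 3 `CCC(=O)N[C@@H]1CCCc2c1cncc2N1C(=O)c2ccc(Cl)cc2[C@@H]1CC` gives 12 nM. For the measured compounds named here, the step of a 2.0-fold higher number from compound 2 to compound 3 (0.30 log units; within the scatter) is the only single-point change measured so far. Compound 3 thus has the highest number of the three, yet its gap to compound 2 is within the scatter, so the two cannot be ordered; only compound 1 sits beyond the scatter, at a lower number.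

Compound 4 `CCC(=O)N[C@@H]1CCCc2c1cncc2N1C(=O)c2ccc(Cl)cc2[C@H]1CC` differs from compound 3 as follows: the two compounds have the same atoms and bonds and differ only in configuration as drawn: 1 of 2 stereo elements differ; a stereocentre at a saturated ring carbon is drawn S in compound 3 and R in compound 4. Going by the values given here, none of the measured steps changes a stereocentre, so no measured step bears directly on this change; the step from compound 2 to compound 3 concerns a change of substituent, not of configuration, and offers no guide to direction. With no inversion of a stereocentre yet measured in the series, the number for compound 4 is uncertain in both directions; it is expected to move by a 2.5-fold higher number from compound 3 to compound 4 (0.40 log units; beyond the scatter), most plausibly towards a higher number. Compound 4 is therefore estimated at 30 nM in this assay, with a range from 6 nM to 150 nM.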

Compound 4, half-maximal inhibitory concentration: 90 nM
Compound 4: middle estimate off by 3.0-fold (0.48 log units), on the low side; the measured number falls inside the stated range.
By their numbers in this assay, from the lowest: compounds 1, 2 and 3 (each within the scatter of the next, the first and the last beyond it); then compound 4.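

For the compounds shown here, at the saturated ring carbon carrying the ethyl group, configuration matters more than anything the earlier compounds could show: in this assay, inversion from the S to the R drawing gives a 7.5-fold higher number from compound 3 to compound 4 (0.88 log units; beyond the scatter). Going by these compounds alone, the earlier single-point change at this carbon, a 2.0-fold higher number from compound 2 to compound 3 (0.30 log units; within the scatter), did not separate its two compounds, so this is the first change at this position to move the number beyond the scatter. The shift can be assigned to this stereocentre alone, because nothing else separates the pair: the fact that compounds 3 and 4 differ only in the configuration as drawn.

Still open, as far as these compounds go, is whether inversion at this carbon has a similar effect when the substituent is the methyl group of compound 2. Also open, from the compounds shown here alone, is how the S and R forms would compare with a longer chain, a hydroxyl group or an amine at this position.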